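Butyl added to the chain of compound 1

A few compounds are considered here, and "the series" means these few. Any claim that something is new, unique, unknown or untested is made for them only; others in the source may bear on it.

In a functional assay on SW480 cells (Homo sapiens) for antiproliferative activity, read by MTT assay, with a stated time of 48 h (on this read-out higher numbers stand for weaker inhibition and lower numbers for stronger inhibition), compound 1 (`CCCCCCC(CCO)n1cnc2c(OC)ncnc21`) gives > 50000 nM, which is a limit. Compound 2 (`CCCCCCC(CCO)n1cnc2c(N)ncnc21`) gives > 50000 nM, also a limit. Compound 3 (`CCCCCCC(CCO)n1cnc2cncnc21`) gives > 50000 nM, again a limit. For the measured compounds named here, compound 1 therefore stands at the limit of > 50000 nM in this assay, at which 3 of the 3 values shown sit, and the series so far holds no readable number.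

Compound 4 (`CCCCCCCCCCC(CCO)n1cnc2c(OC)ncnc21`) keeps the core of compound 1 and changes only the chain: butyl in place of hydrogen on a saturated chain carbon, seven bonds along the chain from an aromatic nitrogen. The added butyl sits on a saturated chain carbon, seven bonds along the chain from an aromatic nitrogen.

Three measured steps are available: a step that the two limits leave unreadable from compound 1 to compound 2, a step that the two limits leave unreadable from compound 1 to compound 3 and a step that the two limits leave unreadable from compound 2 to compound 3. All three replace a group on an aromatic carbon. None alters the chain, and none supplies a size to carry over to this change.

The expectation is therefore weak. A modest move toward stronger inhibition in this assay is expected, resting only on the added butyl, and compound 4 may well report only a limit too. The estimated step is an at least 2.0-fold lower number from compound 1 to compound 4 (0.30 log units; that floor lies within the scatter). Compound 4 is estimated at 25000 nM, with an expected range of 7000 nM to 50000 nM.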

Compound 4, half-maximal inhibitory concentration: 8260 nM
The estimate for compound 4 lay 3.0-fold (0.48 log units) above the measured number; measured number inside the range.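

Butyl in place of hydrogen on a saturated chain carbon, seven bonds along the chain from an aromatic nitrogen, yields the only readable number among the compounds shown in this assay, as an at least 6.0-fold lower number from compound 1 to compound 4 (0.78 log units; beyond the scatter). Compound 1 gives > 50000 nM, which is a limit, so the step has a floor and no upper bound. The steps among compound 1, compound 2 and compound 3 cannot be read, and they all replace a group on an aromatic carbon, so this chain position is the only place in the series where a change is seen to leave the limit that otherwise holds: the limit of > 50000 nM in this assay, at which 3 of the 4 values shown sit.

Compound 2 and compound 3 are shown only with the chain of compound 1, so it remains open whether amino or hydrogen in place of methoxy on an aromatic carbon would move the read-out once the butyl is present. Also open, from the compounds shown here alone, is how the read-out responds at this same chain carbon to an ethyl, a longer chain or a carboxylic acid in place of the butyl, and whether one added group of this kind can take the number lower still.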